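Does a longer chain change inhibition in this series?

The source may hold more compounds than are shown below. What is called first, only, known or untested is meant among the compounds shown, and "the series" means these compounds.

Compound 1 `CCCCOc1ccc(-c2c(C)[nH]c(=O)n2C2CCCCC2)cc1`, compound 2 `CCCCCOc1ccc(-c2c(C)[nH]c(=O)n2C2CCCCC2)cc1` and compound 3 `CCCCCCCOc1ccc(-c2c(C)[nH]c(=O)n2C2CCCCC2)cc1` share one core and differ only in the length of a saturated chain. In a functional assay on brain (Rattus norvegicus, strain Wistar) for inhibition (a lower number here means a stronger inhibitor, a higher number a weaker inhibitor), compound 1 gives 13900 nM, compound 2 gives 9100 nM and compound 3 gives 11600 nM. On these numbers, compound 3 cannot be told apart from either of the other two.

The unmeasured compound 4 `CCCCCCCCCCCCOc1ccc(-c2c(C)[nH]c(=O)n2C2CCCCC2)cc1` extends that chain further: pentyl in place of hydrogen on a saturated chain carbon, seven bonds along the chain from an oxygen on an aromatic ring. Going by the values given here, three measured steps bear on this change: a 1.5-fold lower number from compound 1 to compound 2 (0.18 log units; within the scatter), a 1.2-fold lower number from compound 1 to compound 3 (0.08 log units; within the scatter) and a 1.3-fold higher number from compound 2 to compound 3 (0.11 log units; within the scatter). All three are small, although the new addition is larger than any addition measured so far, so this guide is loose. A step beyond the scatter in this assay is therefore not expected, and neither direction is favoured. The expected change is a 1.2-fold lower number from compound 3 to compound 4 (0.06 log units; within the scatter). For compound 4 the estimate is 10000 nM, with an expected range from 3000 nM to 30000 nM.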

Compound 4, half-maximal inhibitory concentration: 52400 nM
Estimate against measurement, compound 4: 5.2-fold (0.72 log units) below; the whole stated range lies below it.
By their numbers in this assay, from the lowest: compounds 2, 3 and 1 (each within the scatter of the next); then compound 4.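

Up to compound 3, changing the chain length produced no difference that could be read in this assay, but the much longer chain of compound 4 does produce one (a 4.5-fold higher number from compound 3 to compound 4 (0.65 log units; beyond the scatter)). The same holds against the two shorter chains (a 5.8-fold higher number from compound 2 to compound 4 (0.76 log units; beyond the scatter); a 3.8-fold higher number from compound 1 to compound 4 (0.58 log units; beyond the scatter)), so among these four compounds, chain length at this position is tolerated only up to a point, and compound 4 alone stands apart as the weaker inhibitor. Nothing shown here explains why this longer chain behaves differently.

From the compounds shown here alone, whether the number climbs gradually or abruptly across chains of intermediate length, between those of compound 3 and compound 4, remains open. Also open, going by these compounds, is what a chain of similar length ending in an amine or a carboxylic acid would do.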